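The source may hold more compounds than are shown below. What is called first, only, known or untested is meant among the compounds shown, and "the series" means these compounds.

Working notes on the shared core. Compound 1 `O=C1C(Nc2ccccc2)=CC(=O)c2c1nc1n2[C@H]2OC[C@@H](O)[C@H]2OC1` gives 1830 nM in a functional assay on MGC-803 cells (Homo sapiens) for inhibition, read by sulforhodamine B assay; a higher number here means a weaker inhibitor, a lower number a stronger inhibitor. Compound 2 `CCc1ccc(NC2=CC(=O)c3nc4n(c3C2=O)[C@H]2OC[C@@H](O)[C@H]2OC4)cc1` gives 1290 nM in this assay: of the two numbers in hand this is the lowest, and compound 1 sits within the scatter of it, so no order between the two is claimed. Compound 3 `O=C1C(N2CCC2)=CC(=O)c2c1nc1n2[C@H]2OC[C@@H](O)[C@H]2OC1` returns only a limit of this assay, > 16000 nM, not a number. That limit is the one noted as the limit of > 16000 nM in this assay, at which 1 of the 3 values shown sits.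

Going by the values given here, the single measured step that bears on the change now under consideration is an at least 8.7-fold higher number from compound 1 to compound 3 (0.94 log units; beyond the scatter), a swap of the anilino group for a small cyclic amine on the same double-bonded ring carbon.

Compound 4 `O=C1C=C(N2CCCCC2)C(=O)c2c1nc1n2[C@H]2OC[C@@H](O)[C@H]2OC1` differs from compound 2 by piperidin-1-yl in place of (4-ethylphenyl)amino on a double-bonded ring carbon. This is the same kind of exchange, a cyclic amine taking the place of an arylamino group, so a rise of the same order is expected in this assay. Because the matching step an at least 8.7-fold higher number from compound 1 to compound 3 (0.94 log units; beyond the scatter) ended at the limit, compound 4 is also expected to land at or past that limit. The expected step is a 16-fold higher number from compound 2 to compound 4 (1.19 log units; beyond the scatter), beyond the scatter. Compound 4 is therefore estimated at 20000 nM in this assay, with a range from 6000 nM to 60000 nM.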

Compound 4, half-maximal inhibitory concentration: > 8000 nM
Compound 4 ended at the assay's limit; the forecaster's own chance of this, stated with the estimate: 65%; the middle value is on the limit's open side.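

In this assay, replacing an arylamino group with a cyclic amine weakens inhibition for a second pair, giving an at least 6.2-fold higher number from compound 2 to compound 4 (0.79 log units; beyond the scatter). Together with an at least 8.7-fold higher number from compound 1 to compound 3 (0.94 log units; beyond the scatter), this shows that in both pairs the loss is not confined to azetidin-1-yl or to the unsubstituted anilino group, as it also holds for piperidin-1-yl replacing (4-ethylphenyl)amino. Compound 4 returns a limit and not a number, so its step gives only a bound on the true size: the limit of > 8000 nM in this assay, at which 1 of the 4 values shown sits.

Compound 3 and compound 4 both end at limits, so no order between azetidin-1-yl and piperidin-1-yl can be read, and in both pairs the aromatic ring and the hydrogen-bond donor leave together, so the compounds shown cannot say which loss matters. An N-methylanilino group, which keeps the aromatic ring without the amine hydrogen, and a cyclohexylamino group, which keeps the amine hydrogen without the aromatic ring, would separate the two.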